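Shortening the Anilide Linker in a Purine Series

The source may report more compounds than this note shows. Statements on the series, on what has been measured and on what is new or still open speak of the compounds shown alone.

Measured compounds:
compound 1 `CC(C)n1cnc2c(Nc3ccccc3)nc(NCOCc3ccc(C(=O)Nc4ccccc4N)cc3)nc21` – 6.58%
compound 2 `CCCCn1cnc2c(Nc3ccccc3)nc(NCOCc3ccc(/C=C/C(=O)Nc4ccccc4N)cc3)nc21` – 27.9%

In a functional assay on HepG2 cells (Homo sapiens) for antiproliferative activity, read by CCK-8 assay, with a stated time of 72 h, tested at 2 uM (a lower number here means a weaker effect, a higher number a stronger effect of the compound at the concentration tested), compound 2 stands highest of the two numbers, and compound 1 lies beyond the scatter below it. Compound 3 `CCCCn1cnc2c(Nc3ccccc3)nc(NCOCc3ccc(C(=O)Nc4ccccc4N)cc3)nc21` differs from compound 2 in one place: (2-aminophenyl)carbamoyl in place of 2-((2-aminophenyl)carbamoyl)ethenyl on an aromatic carbon. For the measured compounds named here, no step between measured compounds isolates this change. Because compound 1 gives 6.58% while carrying the same (2-aminophenyl)carbamoyl group, a downward step of moderate size is expected, a number 14.9 percentage points lower from compound 2 to compound 3 (beyond the scatter). Compound 3 is therefore estimated at 13%, within a range from 3% to 28%.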

Compound 3, a percentage reported as inhibition, at one concentration (the size of the read-out at that concentration, not a potency): 46.6%
Beside the measured number, compound 3's estimate is 33.6 percentage points below it, outside the stated range (above it).
By their numbers in this assay, from the lowest: compound 1; then compound 2; then compound 3.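

In this assay the shorter (2-aminophenyl)carbamoyl in place of 2-((2-aminophenyl)carbamoyl)ethenyl on the aromatic carbon gives a number 18.7 percentage points higher from compound 2 to compound 3 (beyond the scatter) and so costs nothing at this position with butyl on the nitrogen. With (2-aminophenyl)carbamoyl held in place, butyl in place of isopropyl on the aromatic nitrogen gives a number 40 percentage points higher from compound 1 to compound 3 (beyond the scatter) and shows that the low number of compound 1 does not follow from the shorter group alone. Nothing measured here bears on why either step occurs.

On these data alone, whether a longer chain such as hexyl on that nitrogen raises the number further stays open, as does whether a hydroxamic acid in place of (2-aminophenyl)carbamoyl keeps it.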